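This account rests on a few compounds, and the source may have more. Where it says the series, first, only, none or still open, it means among the compounds named here.

Notes on the series. Compound 1 `O=C(O)c1cc(-c2ccc(-c3ccc(Cl)cc3Cl)cc2)n(Cc2cccnc2)n1` is the (pyridin-3-yl)methyl member. In an assay on isolated protein for inhibition of methionine--tRNA ligase, cytoplasmic (Homo sapiens) (a higher number here means a weaker inhibitor, a lower number a stronger inhibitor), compound 1 returns only a limit, > 100000 nM. Compound 2 `O=C(O)c1cc(-c2ccc(-c3ccc(Cl)cc3Cl)cc2)n(Cc2ccncc2)n1` gives 26200 nM in this assay, and compound 3 `O=C(O)c1cc(-c2ccc(-c3ccc(Cl)cc3Cl)cc2)n(-c2cccnc2)n1` gives 47000 nM. On the numbers shown compound 3 sits alongside compound 2, with a 1.8-fold higher number from compound 2 to compound 3 (0.25 log units; within the scatter); against the limit of compound 1 there is an at least 2.1-fold lower number from compound 1 to compound 3 (0.32 log units; beyond the scatter) and an at least 3.8-fold lower number from compound 1 to compound 2 (0.58 log units; beyond the scatter), so the group on the aromatic nitrogen has so far moved this assay only modestly. Compound 4 `O=C(O)c1cc(-c2ccc(-c3ccc(Cl)cc3Cl)cc2)n(CCO)n1` differs from compound 3 by 2-hydroxyethyl in place of pyridin-3-yl on an aromatic nitrogen. Among the compounds with values here, no measured step exchanges a ring for a short chain at this position. Taking an at least 2.1-fold lower number from compound 1 to compound 3 (0.32 log units; beyond the scatter) and a 1.8-fold higher number from compound 2 to compound 3 (0.25 log units; within the scatter) as the only guidance, a small step toward a higher number is expected, a 1.5-fold higher number from compound 3 to compound 4 (0.17 log units; within the scatter). Compound 4 is therefore estimated at 70000 nM, with a range from 20000 nM to 250000 nM.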

Compound 4, half-maximal inhibitory concentration: > 100000 nM
Compound 4 was reported as a limit (the forecaster's own chance of this, stated with the estimate: 35%); middle value at least 1.4-fold (0.15 log units) from the limit.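

Within the data shown here, the first exchange of a ring for a short chain on the aromatic nitrogen gives an at least 2.1-fold higher number from compound 3 to compound 4 (0.32 log units; beyond the scatter) and an at least 3.8-fold higher number from compound 2 to compound 4 (0.58 log units; beyond the scatter). In this assay, among these compounds, measurable values at this position so far come only from members carrying a pyridinyl ring, though compound 1 goes against this by carrying such a ring and still returning a limit. The step between compound 1 and compound 4 cannot be read, as both values are limits: the limit of > 100000 nM in this assay, at which 2 of the 4 values shown sit.

The compounds shown leave open whether a benzyl group or a 2-aminoethyl chain on this nitrogen would give a measurable value. The separate parts played by the pyridinyl nitrogen and the hydroxy group therefore remain unresolved.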